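Trifluoromethoxy in Place of Trifluoromethyl on a Shared Core

The source may hold more compounds than are shown below. What is called first, only, known or untested is meant among the compounds shown, and "the series" means these compounds.

Compound 1 `Oc1cccc(-c2cc(-c3ccccc3C(F)(F)F)cc(-c3ccccc3O)n2)c1` has been tested in a functional assay on HeLa cells (Homo sapiens) for inhibition (on this read-out lower numbers stand for stronger inhibition and higher numbers for weaker inhibition), where compound 1 gives 16800 nM. For the measured compounds named here, the only other measured member of the series is compound 2 `Oc1ccc(-c2cc(-c3ccccc3C(F)(F)F)cc(-c3ccccc3O)n2)cc1`, which in this assay gives 16500 nM. Going by the values given here, the single measured step, a 1.0-fold lower number from compound 1 to compound 2 (0.01 log units; within the scatter), replaces one hydroxyphenyl by another and leaves the two compounds indistinguishable within the scatter, so compound 1 is one of a pair that cannot be told apart on the numbers so far.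

Compound 3 `Oc1cccc(-c2cc(-c3ccccc3OC(F)(F)F)cc(-c3ccccc3O)n2)c1` is not yet measured. It differs from compound 1 by trifluoromethoxy in place of trifluoromethyl on an aromatic carbon. Among the compounds with values here, no measured step touches this part of the molecule: the step from compound 1 to compound 2 concerns a different ring and offers no guidance on the trifluoromethoxy for trifluoromethyl exchange. With nothing in the data pointing either way, the expected step is a 1.1-fold lower number from compound 1 to compound 3 (0.02 log units; within the scatter), that is, no change beyond the scatter in either direction. On that basis compound 3 is estimated to give 16000 nM in this assay, within a range from 6000 nM to 45000 nM.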

Compound 3, half-maximal inhibitory concentration: 15200 nM
Beside the measured number, compound 3's estimate is 1.1-fold (0.02 log units) above it, and the stated range covers the measured number.
By their numbers in this assay, from the lowest: compounds 3, 2 and 1 (each within the scatter of the next).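

In this assay, trifluoromethoxy in place of trifluoromethyl, on an aromatic carbon ortho to a large group, amounts to a 1.1-fold lower number from compound 1 to compound 3 (0.04 log units; within the scatter). For the compounds shown here, this is the first measured change at this position, and it shows that the exchange, which brings in a group that counts a hydrogen-bond acceptor where trifluoromethyl counts none, does not separate compound 3 from compound 1 on this read-out. No measurement bears on why these two groups give numbers that cannot be told apart.

Going by these compounds alone, what remains open is whether this position responds to any change at all, since the only exchange seen here keeps a fluorinated group in place, and an amine, a carboxylic acid or a longer chain such as butoxy could give a different answer. As far as these compounds go, it is equally open whether the hydroxyl groups on the other two aryl rings of the shared core matter to the number, as a methoxy in place of either one would begin to show.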